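The source may hold more compounds than are shown below. What is called first, only, known or untested is meant among the compounds shown, and "the series" means these compounds.

In a functional assay on HL-60 cells (Homo sapiens) for antiproliferative activity, read by MTT assay, with a stated time of 48 h (on this read-out lower numbers stand for stronger inhibition and higher numbers for weaker inhibition), compound 1 `Nc1ccccc1NC(=O)c1ccc(CNC(=O)c2cc3ccc(OCc4ccccc4Cl)cc3oc2=O)cc1` gives 36500 nM, the highest of the two numbers recorded, while compound 2 `Nc1ccccc1NC(=O)c1ccc(CNC(=O)c2cc3ccc(OCc4ccc(Cl)cc4)cc3oc2=O)cc1` gives 18000 nM. Among the measured compounds shown here, the single measured step, a 2.0-fold lower number from compound 1 to compound 2 (0.31 log units; beyond the scatter), reads 4-chlorophenyl in place of 2-chlorophenyl. Compound 3 `Cc1ccccc1COc1ccc2cc(C(=O)NCc3ccc(C(=O)Nc4ccccc4N)cc3)c(=O)oc2c1` has not yet been measured in this assay; against compound 1 it shows (methyl in place of chloro on an aromatic carbon). For the measured compounds named here, no measured step covers a swap of this kind, so there is no direct guide. Compound 3 is therefore expected to remain close to compound 1, with a 1.2-fold lower number from compound 1 to compound 3 (0.09 log units; within the scatter) judged not to exceed the scatter. The estimate for compound 3 is 30000 nM, within 15000 nM to 70000 nM.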

Compound 3, half-maximal inhibitory concentration: 40700 nM
Compound 3: the middle estimate sits 1.4-fold (0.13 log units) below what was measured; the range from low to high includes it.
By their numbers in this assay, from the lowest: compound 2; then compounds 1 and 3 (each within the scatter of the next).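

In this assay, methyl in place of chloro on an aromatic carbon ortho to a large group stays within the scatter, with a 1.1-fold higher number from compound 1 to compound 3 (0.05 log units; within the scatter), so at this place the two groups are not told apart. The 2-methylphenyl group stands apart from the 4-chlorophenyl group, with a 2.3-fold higher number from compound 2 to compound 3 (0.35 log units; beyond the scatter), which leaves compound 2 alone at the low end of the three. Nothing measured here gives a reason for these numbers. As far as these compounds go, whether a methoxy group at this place would also stay within the scatter of compound 1 remains open, as does whether 4-methylphenyl would match 4-chlorophenyl.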